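Replacing thiomorpholin-4-yl with piperidin-1-yl: what to expect

This account rests on a few compounds, and the source may have more. Where it says the series, first, only, none or still open, it means among the compounds named here.

Compound 1 `N/C(=N\NC(=S)N1CCOCC1)c1ccccn1` gives 40% in a functional assay on HeLa cells (Homo sapiens) for cytotoxicity, read by MTT assay, with a stated time of 72 h, tested at 3 uM (on this read-out higher numbers stand for more inhibition of growth at the one concentration tested and lower numbers for less inhibition of growth), and compound 2 `N/C(=N\NC(=S)N1CCSCC1)c1ccccn1` gives 39.7%. The change a number 0.3 percentage points lower from compound 1 to compound 2 (within the scatter) lies within the scatter, so compound 2 stands alongside compound 1 rather than apart from it. Compound 3 `N/C(=N\NC(=S)N1CCCCC1)c1ccccn1` differs from compound 2 by piperidin-1-yl in place of thiomorpholin-4-yl on a thiocarbonyl carbon. Among the compounds with values here, the only step that bears on this, from morpholin-4-yl to thiomorpholin-4-yl at the same position, was a number 0.3 percentage points lower from compound 1 to compound 2 (within the scatter), so no step beyond the scatter is expected, and the estimated step is a number 1.7 percentage points lower from compound 2 to compound 3 (within the scatter). Compound 3 is therefore expected to give about 38%, within a range of 24% to 52%.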

Compound 3, percent growth inhibition at one concentration: 49.2%
For compound 3 the middle estimate is 11.2 percentage points below the measured one; low and high end bracket the measured number.
By their numbers in this assay, from the lowest: compounds 2, 1 and 3 (each within the scatter of the next).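

In this assay the ring on the thiocarbonyl carbon now has one hetero atom instead of two, and the read-out gives a number 9.5 percentage points higher from compound 2 to compound 3 (within the scatter) and a number 9.2 percentage points higher from compound 1 to compound 3 (within the scatter). Within the data shown here, earlier, only one ring hetero atom had been exchanged for another; these steps show that piperidin-1-yl, with neither the oxygen nor the sulfur, also stays within the scatter at this position. No measurement at hand speaks to what lies behind these numbers. On these data alone, whether an open-chain diethylamino group or a piperazin-1-yl ring on the same carbon would also stay within the scatter remains open.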